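This account rests on a few compounds, and the source may have more. Where it says the series, first, only, none or still open, it means among the compounds named here.

Measured so far in a functional assay on the whole organism for inhibition, with Rattus norvegicus as the target, read by cytopathic effect and paw edema, at a dose of 100 mg/kg by the oral route; a higher number here means more inhibition at the dose given (going by the name of the read-out), a lower number less inhibition:
compound 1 `CCOC(=O)c1c(O)c2cccnc2n(-c2ccccc2)c1=O` — 15.5%
compound 2 `CN(C)CCNC(=O)c1c(O)c2cccnc2n(-c2ccccc2)c1=O` — 18.4%

Compound 1 stands at the lower of the two numbers in this assay, with compound 2 the nearest, and the step of a number 2.9 percentage points higher from compound 1 to compound 2 (within the scatter) lies within the scatter, so the two values cannot be ordered.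

The unmeasured compound is compound 3 `O=C(Nc1cccc([N+](=O)[O-])c1)c1c(O)c2cccnc2n(-c2ccccc2)c1=O`. It differs from compound 1 as follows: (3-nitrophenyl)amino in place of ethoxy on a carbonyl carbon

Among the measured compounds shown here, the one measured step that bears on this change is the one in which the ethoxy on the same carbonyl carbon is exchanged for an amine-bearing group: a number 2.9 percentage points higher from compound 1 to compound 2 (within the scatter). That exchange left the read-out within the scatter. The change to compound 3 is of the same kind at the same place, the entering group differing in that it carries a carbon-only aromatic ring with a nitro group rather than an aliphatic chain. For the measured compounds named here, no measured step speaks to what that ring does here. On the evidence available, the expected step in this assay is a number 4.5 percentage points higher from compound 1 to compound 3 (within the scatter), which is no step beyond the scatter.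

Compound 3 is therefore estimated at 20%, with a range of 5% to 40%, in this assay.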

Compound 3, a percentage reported as inhibition, in the whole organism at one dose (the size of the read-out at that dose, not a potency): 7.4%
The estimate for compound 3 lay 12.6 percentage points above the measured number, within the range that was stated.
By their numbers in this assay, from the lowest: compounds 3, 1 and 2 (each within the scatter of the next, the first and the last beyond it).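

In this assay, (3-nitrophenyl)amino in place of ethoxy on the carbonyl carbon gives a number 8.1 percentage points lower from compound 1 to compound 3 (within the scatter), so the anilide-type amide and the ethyl ester cannot be ordered at this dose. With 3-nitrophenyl in place of 2-(dimethylamino)ethyl on the amide-type nitrogen, the series gives a number 11 percentage points lower from compound 2 to compound 3 (beyond the scatter), the one step among these compounds beyond the scatter, which shows that the group on this nitrogen can move the read-out, though only modestly. Nothing at hand accounts for this step.

From the compounds shown here alone, whether the step belongs to the nitro group or to the aromatic ring itself remains open, and a plain phenylamino group on the same carbonyl carbon would separate the two. Also open, going by these compounds, is whether a longer aliphatic chain carrying a dimethylamino group, or a benzylamino group, at this carbonyl carbon would bring the read-out clear of the scatter around compound 1 in this assay, where every value shown so far remains low.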